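The source may report more compounds than this note shows. Statements on the series, on what has been measured and on what is new or still open speak of the compounds shown alone.

Measured compounds:
compound 1 `CCC(=O)c1ccc2c(c1)C(n1ccccc1=O)=CC(C)(C)O2` — 6.63
compound 2 `CC1(C)C=C(n2ccccc2=O)c2cc(C(=O)c3ccc(O)cc3)ccc2O1` — 6.65

In a functional assay (aorta) with Rattus norvegicus as the target (on this read-out higher numbers stand for higher potency (the scale is a negative logarithm) and lower numbers for lower potency), compound 1 gives 6.63; compound 2 gives 6.65, so the two stand within the usual scatter of each other, with a number 0.02 log units higher from compound 1 to compound 2 (within the scatter). Compound 3 `CC1(C)C=C(n2ccccc2=O)c2cc(C(=O)c3c(F)cccc3F)ccc2O1` differs from compound 1 by 2,6-difluorophenyl in place of ethyl on a carbonyl carbon. Among the measured compounds shown here, the only step that bears on this, an aromatic ring in place of ethyl on the same carbonyl carbon, was a number 0.02 log units higher from compound 1 to compound 2 (within the scatter). A step of about that size, none beyond the scatter, is therefore expected for compound 3, namely a number 0.07 log units higher from compound 1 to compound 3 (within the scatter). Compound 3 is estimated at 6.7, in the range 6.2 to 7.2.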

Compound 3, logarithm of the reciprocal of the active concentration, log(1/C): 6.97
Compound 3: the middle estimate sits 0.27 log units below what was measured, and the stated range covers the measured number.
By their numbers in this assay, from the lowest: compounds 1 and 2 (each within the scatter of the next); then compound 3.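

In this assay the group on the carbonyl carbon now shifts the number beyond the scatter: 2,6-difluorophenyl gives a number 0.34 log units higher from compound 1 to compound 3 (beyond the scatter) and also a number 0.32 log units higher from compound 2 to compound 3 (beyond the scatter) even though the earlier change from ethyl to 4-hydroxyphenyl stayed within it. An aromatic ring at this place is therefore not enough on its own, and the outcome differs between the two aromatic groups shown. Nothing measured here accounts for the gain.

Going by these compounds, whether the step depends on the fluorines or on the ring and its substitution remains open. Unsubstituted phenyl, or a phenyl carrying chlorine or an amine, would help separate these.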